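Swapping a Pyridine for a Lactam: Solubility Outlook

The compounds below may be only part of what the source reports. "The series", "measured", "known", "first", "only" and "open" are said of these compounds alone.

Compound 1 `Cc1noc(-c2nc(C)c3c(c2N)C(=O)N(Cc2ccc(-c4ccncc4)cc2)C3=O)n1`: < 5000 nM in a physicochemical assay for solubility, using the shake flask method, in simulated intestinal fluid, measured as kinetic solubility, with a stated time of 2 h, at 25 degrees C, at pH 6.5; on this read-out lower numbers stand for lower solubility and higher numbers for higher solubility.
Compound 2 `Cc1noc(-c2nc(C)c3c(c2N)C(=O)N(CC2CCNCC2)C3=O)n1`: 160000 nM.
Compound 3 `Cc1noc(-c2nc(C)c3c(c2N)C(=O)N(C(C)c2ccccc2)C3=O)n1`: 10900 nM.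

Going by the values given here, the value for compound 1 is a limit of this assay, not a number; it tells only that compound 1 sits at the limit of < 5000 nM in this assay, at which 1 of the 3 values shown sits. Compound 4 `Cc1noc(-c2nc(C)c3c(c2N)C(=O)N(Cc2ccc(N4CCCC4=O)cc2)C3=O)n1` differs from compound 1 by 2-oxopyrrolidin-1-yl in place of pyridin-4-yl on an aromatic carbon. Among the compounds with values here, the only measured step, a 15-fold lower number from compound 2 to compound 3 (1.17 log units; beyond the scatter), changes the group on the amide-type nitrogen in a ring, a different place in the shared core, so no measured step bears directly on this change. Compound 4 is therefore expected to give 6000 nM, with a range from 1500 nM to 30000 nM. That estimate corresponds to an expected step of an at least 1.2-fold higher number from compound 1 to compound 4 (0.07 log units; that floor lies within the scatter).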

Compound 4, solubility: < 5000 nM
Compound 4 ended at the assay's limit; the forecaster's own chance of this, stated with the estimate: 40%; middle value at least 1.2-fold (0.07 log units) away from the limit.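

Compound 1 and compound 4 both end at a limit of this assay, not at a number, so no step between them can be read: the limit of < 5000 nM in this assay, at which 2 of the 4 values shown sit.

The compounds shown leave open whether 2-oxopyrrolidin-1-yl in place of pyridin-4-yl changes this reading at all.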